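The source may hold more compounds than are shown below. What is called first, only, known or untested is meant among the compounds shown, and "the series" means these compounds.

Measured so far:
- Compound 1, `Cc1nc2c3ccccc3ccc2c2nc3c(ccc4ccccc43)c(-c3cccc([N+](=O)[O-])c3)c12`: 13200 nM
- Compound 2, `Cc1nc2c3ccccc3ccc2c2nc3c(ccc4ccccc43)c(-c3cccc4ccccc34)c12`: 20800 nM
- Compound 3, `Cc1nc2c3ccccc3ccc2c2nc3c(ccc4ccccc43)c(-c3ccccc3N)c12`: 4760 nM

All three were tested in a functional assay on HCT-116 cells (Homo sapiens) for cytotoxicity, read by MTT assay, with a stated time of 48 h; on this read-out lower numbers stand for stronger inhibition and higher numbers for weaker inhibition. Compound 3 gives the lowest number of the three; the step of a 2.8-fold lower number from compound 1 to compound 3 (0.44 log units; beyond the scatter) and the step of a 4.4-fold lower number from compound 2 to compound 3 (0.64 log units; beyond the scatter) both lie beyond the scatter, so compound 3 stands clearly apart as the strongest inhibitor in this small set. Compound 4, `Cc1ccc(-c2c3ccc4ccccc4c3nc3c2c(C)nc2c4ccccc4ccc32)cc1`, has not been measured. It differs from compound 3 in one place: 4-methylphenyl in place of 2-aminophenyl on an aromatic carbon. Among the measured compounds shown here, two measured steps bear on this change, since both compound 1 and compound 2 carry a group other than 2-aminophenyl in the same place, and both give higher numbers than compound 3. Neither of those groups is 4-methylphenyl, so the comparison is indirect. Still, a step back toward the numbers of compound 1 and compound 2 seems the most reasonable expectation. The step from compound 3 to compound 4 is therefore expected to be a 2.5-fold higher number from compound 3 to compound 4 (0.40 log units; beyond the scatter), a modest rise. Compound 4 is estimated at 12000 nM, with a likely range from 5000 nM to 30000 nM.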

Compound 4, half-maximal inhibitory concentration: 67000 nM
Compound 4: middle estimate off by 5.6-fold (0.75 log units), on the low side, outside the stated range (above it).
By their numbers in this assay, from the lowest: compound 3; then compounds 1 and 2 (each within the scatter of the next); then compound 4.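

Swapping 2-aminophenyl for 4-methylphenyl in this assay has the largest effect seen so far at this position (a step of a 14-fold higher number from compound 3 to compound 4 (1.15 log units; beyond the scatter)), even though the two groups have the same number of heavy atoms and the same six-membered carbon ring. Compound 4 also gives a clearly higher number than the other two compounds (steps of a 3.2-fold higher number from compound 2 to compound 4 (0.51 log units; beyond the scatter) and a 5.1-fold higher number from compound 1 to compound 4 (0.71 log units; beyond the scatter)), so it is the weakest inhibitor of the four, and this position can weaken activity well beyond what the earlier groups showed. Nothing measured here explains this rise.

The change both removes the amine and alters where the ring carries its substituent, so these compounds cannot show which of the two matters. Comparing 4-aminophenyl and 2-methylphenyl at this position would separate those two differences.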